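From Methoxy to Phenyl: a Single Change Toward Compound 3

A few compounds are considered here, and "the series" means these few. Any claim that something is new, unique, unknown or untested is made for them only; others in the source may bear on it.

compound 1 `COc1ccc2c(ccn2S(=O)(=O)c2ccccc2)c1`: 127 nM
compound 2 `O=S(=O)(c1ccccc1)n1cc(N2CCCCC2)c2ccccc21`: 219 nM

In an assay on isolated protein for displacement of a labelled ligand from 5-hydroxytryptamine receptor 6 (Homo sapiens), read by scintillation counting, with a stated time of 1 h (on this read-out higher numbers stand for weaker inhibition and lower numbers for stronger inhibition), compound 1 gives the lower of the two numbers, and compound 2 sits somewhat higher, a gap that stays within the usual scatter. Compound 3 `O=S(=O)(c1ccccc1)n1ccc2cc(-c3ccccc3)ccc21` has not yet been measured. It differs from compound 1 in one place: phenyl in place of methoxy on an aromatic carbon. For the measured compounds named here, no measured pair shows what this change does here, so the expectation rests on the two numbers alone. A modest step in this assay, leaning toward a weaker result, is expected. Compound 3 is estimated at 250 nM, with a range from 60 nM to 1000 nM. This expected change amounts to a 2.0-fold higher number from compound 1 to compound 3 (0.29 log units; within the scatter).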

Compound 3, inhibition constant: 558 nM
The estimate for compound 3 lay 2.2-fold (0.35 log units) below the measured number; low and high end bracket the measured number.
By their numbers in this assay, from the lowest: compounds 1 and 2 (each within the scatter of the next); then compound 3.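

Phenyl in place of methoxy on this aromatic carbon gives a 4.4-fold higher number from compound 1 to compound 3 (0.64 log units; beyond the scatter) in this assay, so the position is not indifferent to what it carries. For the compounds shown here, the earlier compounds offered no measured pair at this place; this is the first, and its step is modest yet clear of the scatter. Nothing available explains why the number rises. On these data alone, whether fluorine, a hydroxyl or an amine on this same carbon would match the number of compound 1 or pass it remains open.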